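Chloro to tert-butoxy: the next step in the series

The source may report more compounds than this note shows. Statements on the series, on what has been measured and on what is new or still open speak of the compounds shown alone.

Measured so far:
compound 1 `COc1ccc(-c2nnc(SCCCN3CCN(c4nc5ccccc5o4)CC3)o2)cc1`: 210000 nM
compound 2 `Clc1ccc(-c2nnc(SCCCN3CCN(c4nc5ccccc5o4)CC3)o2)cc1`: 101000 nM

Both values come from a functional assay on HeLa cells (Homo sapiens) for inhibition, read by MTT assay, with a stated time of 72 h; on this read-out higher numbers stand for weaker inhibition and lower numbers for stronger inhibition. Of the two compounds, compound 2 has the lower number and therefore the stronger inhibition, at 101000 nM. Next in line is compound 3 `CC(C)(C)Oc1ccc(-c2nnc(SCCCN3CCN(c4nc5ccccc5o4)CC3)o2)cc1`, which has tert-butoxy in place of chloro on an aromatic carbon.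

For the measured compounds named here, only one measured step bears on this change: a 2.1-fold lower number from compound 1 to compound 2 (0.32 log units; beyond the scatter), with chloro in place of methoxy on an aromatic carbon. Read in reverse, this step suggests that replacing chloro with an oxygen-linked group may raise the number, since compound 1, which carries methoxy, gives 210000 nM. However, this rests on a single pair, and no measured compound carries a group as large as tert-butoxy. A small move towards a higher number is therefore expected in this assay, no larger than the measured step and possibly within the scatter. The expected change is a 1.6-fold higher number from compound 2 to compound 3 (0.20 log units; within the scatter). The estimate for compound 3 is 160000 nM, with an expected range of 70000 nM to 350000 nM.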

Compound 3, half-maximal inhibitory concentration: 269000 nM
For compound 3 the middle estimate is 1.7-fold (0.23 log units) below the measured one, within the range that was stated.
By their numbers in this assay, from the lowest: compound 2; then compounds 1 and 3 (each within the scatter of the next).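

In this assay, tert-butoxy in place of chloro gives a 2.7-fold higher number from compound 2 to compound 3 (0.43 log units; beyond the scatter), so chloro at this position now stands apart from two oxygen-linked groups, not from methoxy alone. Tert-butyl in place of methyl on the oxygen gives a 1.3-fold higher number from compound 1 to compound 3 (0.11 log units; within the scatter), so the two oxygen-linked groups are not separated beyond the usual scatter of this read-out, despite the difference between them. Nothing available accounts for either step.

The compounds shown leave open whether the gap belongs to chloro itself or to the oxygen link: chloro is the only group here without that link, and bromo, fluoro or methyl at the same position would help separate the two readings. From the compounds shown here alone, how an amine or a carboxylic acid would read at this position also remains open, as does whether a longer chain on the oxygen would stay level with compound 1 and compound 3.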